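Isobutyl in place of phenyl: estimate for compound 3

This account rests on a few compounds, and the source may have more. Where it says the series, first, only, none or still open, it means among the compounds named here.

In a physicochemical assay for lipophilicity, read by HPLC, using the shake flask method (a lower number here means a more polar compound, a higher number a more lipophilic compound), compound 2 `CN(Cc1ccc(Cl)nc1)/C(=N/C#N)c1ccccc1` gives 1.86 and compound 1 `CCCC/C(=N\C#N)N(C)Cc1ccc(Cl)nc1` gives 1.87, so the two values lie within the scatter of each other. Compound 3 `CC(C)C/C(=N\C#N)N(C)Cc1ccc(Cl)nc1`, not yet measured, carries isobutyl in place of phenyl on a carbon with a double bond to nitrogen. Among the compounds with values here, the only measured step at this place, phenyl in place of butyl, is a number 0.01 log units lower from compound 1 to compound 2 (within the scatter). On that basis, no change beyond the scatter is expected in this assay, and the estimated step is a number 0.06 log units lower from compound 2 to compound 3 (within the scatter). For compound 3 the expected value is 1.8, within an estimated range of 1.55 to 2.05.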

Compound 3, partition coefficient: 1.75
The estimate for compound 3 lay 0.05 log units above the measured number, and the stated range covers the measured number.
By their numbers in this assay, from the lowest: compounds 3, 2 and 1 (each within the scatter of the next).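

In this assay, isobutyl in place of phenyl gives a number 0.11 log units lower from compound 2 to compound 3 (within the scatter), and isopropyl in place of propyl on a saturated chain carbon bound to a carbon with a double bond to nitrogen gives a number 0.12 log units lower from compound 1 to compound 3 (within the scatter). Butyl, phenyl and isobutyl on this carbon therefore all lie within the scatter of one another, so neither removing the aromatic ring nor changing the chain to isobutyl separates the values here. No supporting data bear on this result. From the compounds shown here alone, it remains open whether an amine, a carboxylic acid or a longer chain at this place would give a step beyond the scatter.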